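This account rests on a few compounds, and the source may have more. Where it says the series, first, only, none or still open, it means among the compounds named here.

Working notes on the series. In an assay on HEK293 cells for negative allosteric modulation of metabotropic glutamate receptor 5 (Homo sapiens), read by FLIPR (on this read-out lower numbers stand for stronger inhibition and higher numbers for weaker inhibition), compound 3 `O=C(C1CCCO1)N1CC(c2nc(-c3cccc(Cl)c3)no2)C1` gives 890 nM. Compound 2 `Cc1cccc(S(=O)(=O)N2CC(c3nc(-c4cccc(Cl)c4)no3)C2)c1`, which carries a sulfonyl group on the shared core rather than a carbonyl, gives 390 nM in this assay. Among the compounds with values here, compound 1 `O=C(C1CCC(F)(F)CC1)N1CC(c2nc(-c3cccc(F)c3)no2)C1` returns only > 10000 nM in this assay, which is a limit and not a number; it is the one value that sits at the limit of > 10000 nM in this assay, at which 1 of the 3 values shown sits. Among the two numbers shown, compound 3 stands highest, and compound 2, the nearest, lies beyond the usual scatter below it.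

Compound 4 `O=C(c1ccccc1F)N1CC(c2nc(-c3cccc(Cl)c3)no2)C1` differs from compound 3 in one place: 2-fluorophenyl in place of oxolan-2-yl on a carbonyl carbon. Within the data shown here, no step between measured compounds covers this replacement, so the direction rests on no measured pair. The step from compound 3 to compound 4 is expected to be a modest move toward a lower number, a 3.0-fold lower number from compound 3 to compound 4 (0.47 log units; beyond the scatter), beyond the scatter but not large. Compound 4 is estimated at 300 nM in this assay, with a range from 80 nM to 1500 nM.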

Compound 4, half-maximal inhibitory concentration: 670 nM
Compound 4: the middle estimate sits 2.2-fold (0.35 log units) below what was measured, within the range that was stated.
By their numbers in this assay, from the lowest: compounds 2, 4 and 3 (each within the scatter of the next, the first and the last beyond it). At a limit, above all of these: compound 1.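

In this assay, 2-fluorophenyl in place of oxolan-2-yl on a carbonyl carbon gives a 1.3-fold lower number from compound 3 to compound 4 (0.12 log units; within the scatter), so this read-out does not tell the two groups apart at this place. The pair shows that a six-membered aromatic ring of carbon only and a five-membered non-aromatic ring with 1 hetero atom can stand on this carbonyl carbon with numbers inside the scatter of each other, although the entering group has no hydrogen-bond acceptor and the leaving group has one. Nothing measured in this set gives a cause for this result.

Still open, as far as these compounds go, is whether an amine, a carboxylic acid or an open alkyl chain on the same carbonyl carbon would keep the number in this range. Also open, from the compounds shown here alone, is whether unsubstituted phenyl would differ from 2-fluorophenyl at this place.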